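Swapping pyridin-2-yl for pyridin-4-yl on a shared core

The source may hold more compounds than are shown below. What is called first, only, known or untested is meant among the compounds shown, and "the series" means these compounds.

Compound 1 `COc1ccccc1-c1nnc(SCCn2c([N+](=O)[O-])cnc2C)o1`: 10000 nM
Compound 2 `Cc1ncc([N+](=O)[O-])n1CCSc1nnc(-c2ccc(N)cc2)o1`: 6700 nM
Compound 3 `Cc1ncc([N+](=O)[O-])n1CCSc1nnc(-c2ccccn2)o1`: 20200 nM

These values come from a functional assay on HepG2 cells (Homo sapiens) for cytotoxicity, read by MTT assay, with a stated time of 48 h; a higher number here means a weaker inhibitor, a lower number a stronger inhibitor. Compound 3 has the highest number of the three, which makes it the weakest inhibitor here. The two steps that reach it are a 2.0-fold higher number from compound 1 to compound 3 (0.31 log units; beyond the scatter) and a 3.0-fold higher number from compound 2 to compound 3 (0.48 log units; beyond the scatter). In each, pyridin-2-yl takes the place of a substituted phenyl group.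

Compound 4 `Cc1ncc([N+](=O)[O-])n1CCSc1nnc(-c2ccncc2)o1` carries pyridin-4-yl in place of pyridin-2-yl on an aromatic carbon. The two compounds have the same atoms, joined differently. For the measured compounds named here, no measured pair makes this kind of swap, so the evidence is indirect. The two steps above are modest, and they show only how far the number moves when this group changes. Compound 3 sits at the top of the set, so a small drift toward compound 1 at 10000 nM seems more likely than a further rise. The expected change is a 1.4-fold lower number from compound 3 to compound 4 (0.16 log units; within the scatter), so no clear shift in this assay is anticipated. For compound 4 the estimated value is 14000 nM, with an expected range of 6000 nM to 32000 nM.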

Compound 4, half-maximal inhibitory concentration: 14800 nM
Compound 4: middle estimate off by 1.1-fold (0.02 log units), on the low side; low and high end bracket the measured number.
By their numbers in this assay, from the lowest: compounds 2, 1, 4 and 3 (each within the scatter of the next, the first and the last beyond it).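

In this assay, exchanging pyridin-2-yl for pyridin-4-yl joins the same atoms differently and gives a 1.4-fold lower number from compound 3 to compound 4 (0.14 log units; within the scatter) on this carbon of the shared core, so this assay does not separate the two groups. The 2-methoxyphenyl group is not separated from pyridin-4-yl either, with a 1.5-fold higher number from compound 1 to compound 4 (0.17 log units; within the scatter) here, whereas 4-aminophenyl does stand apart from pyridin-4-yl, with a 2.2-fold higher number from compound 2 to compound 4 (0.34 log units; beyond the scatter) as the step. Nothing measured here explains why these steps differ in size.

From the compounds shown here alone, whether the amine of the 4-aminophenyl group is what sets compound 2 apart remains open, and plain phenyl at this carbon would help test that. Going by these compounds, how pyridin-3-yl, a carboxylic acid or a longer chain would behave at the same place also remains open.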